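Aryl sulfonyl piperazine carbamates: pyridyl ether replacement

The source may report more compounds than this note shows. Statements on the series, on what has been measured and on what is new or still open speak of the compounds shown alone.

Measured so far:
- compound 1, `O=C(Oc1ccc([N+](=O)[O-])cc1)N1CCN(S(=O)(=O)c2ccc(C3CCCCC3)cc2)CC1`: 333 nM
- compound 2, `O=C(Oc1ccc([N+](=O)[O-])cc1)N1CCN(S(=O)(=O)c2ccc(Oc3cccc(Cl)c3)cc2)CC1`: 380 nM

In an assay on isolated protein for inhibition of Fatty-acid amide hydrolase 1 (Homo sapiens), read by fluorescence (on this read-out higher numbers stand for weaker inhibition and lower numbers for stronger inhibition), compound 2 gives 380 nM and stands as the higher of the two numbers, its nearest neighbour being compound 1, which in this assay gives 333 nM; the two lie within the scatter of each other. Within the data shown here, the one measured step, a 1.1-fold higher number from compound 1 to compound 2 (0.06 log units; within the scatter), swapped a saturated ring for an aryl ether and moved the number hardly at all.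

Compound 3, `O=C(Oc1ccc([N+](=O)[O-])cc1)N1CCN(S(=O)(=O)c2ccc(Oc3ncc(C(F)(F)F)cc3Cl)cc2)CC1`, carries the change (3-chloro-5-(trifluoromethyl)pyridin-2-yl in place of 3-chlorophenyl on an oxygen on an aromatic ring). Among the measured compounds shown here, no measured pair shows an aryl-to-pyridyl exchange on the ether oxygen, so the step from compound 1 to compound 2 bears on it only in that variation at this position has so far left this assay unchanged. The expectation for compound 3 is therefore a step of a 1.1-fold lower number from compound 2 to compound 3 (0.04 log units; within the scatter), not beyond the scatter. Compound 3 is estimated at 350 nM, in the range 120 nM to 1000 nM.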

Compound 3, half-maximal inhibitory concentration: 2950 nM
Beside the measured number, compound 3's estimate is 8.4-fold (0.93 log units) below it, outside the stated range (above it).
By their numbers in this assay, from the lowest: compounds 1 and 2 (each within the scatter of the next); then compound 3.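

In this assay this position is no longer silent: the exchange of cyclohexyl for 3-chlorophenoxy stayed within the scatter, whereas a 7.8-fold higher number from compound 2 to compound 3 (0.89 log units; beyond the scatter) lies beyond it and goes toward weaker inhibition. Against the saturated ring the shift is likewise beyond the scatter, with an 8.9-fold higher number from compound 1 to compound 3 (0.95 log units; beyond the scatter) on record, and compound 2 carries the same ether oxygen without such a shift, so the oxygen link alone does not go with the higher number. No measurement at hand accounts for the step.

The entering group differs from 3-chlorophenyl by both the ring nitrogen and the trifluoromethyl, so the compounds shown cannot assign the step to either one. A 3-chloropyridin-2-yl or a 3-chloro-5-(trifluoromethyl)phenyl group on the same oxygen would separate the two.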